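Adding Iodine Beside the Phenol of a Thiourea Antagonist

A few compounds are considered here, and "the series" means these few. Any claim that something is new, unique, unknown or untested is made for them only; others in the source may bear on it.

Compound 1 `COc1cc(CNC(=S)NC(CCc2ccc(C(C)(C)C)cc2)COC(=O)C(C)(C)C)ccc1O` has no reported result in a functional assay on CHO cells for antagonist activity at transient receptor potential cation channel subfamily V member 1 (Rattus norvegicus); on this read-out lower numbers stand for stronger inhibition and higher numbers for weaker inhibition; for compound 1 the entry reads "not evaluated" (no result reported), so it stands without a number. Compound 2 `COc1cc(CNC(=S)NCC(COC(=O)C(C)(C)C)Cc2ccc(C)c(C)c2)cc(Cl)c1O` likewise has no result in this assay, where compound 2 stands as "not evaluated" (no result reported). Only compound 3 `COc1cc(CNC(=S)NCC(COC(=O)C(C)(C)C)Cc2ccc(C)c(C)c2)c(I)cc1O`, which carries iodine on the same aromatic ring but at a different carbon, has been measured: in this assay compound 3 gives 23.1 nM. Compound 4 `COc1cc(CNC(=S)NC(CCc2ccc(C(C)(C)C)cc2)COC(=O)C(C)(C)C)cc(I)c1O` differs from compound 1 by iodo in place of hydrogen on an aromatic carbon. For the measured compounds named here, with no number for compound 1, no step can be given, and the direction of the change is read only from compound 3. Because compound 3 reaches 23.1 nM with an iodine on this ring, compound 4 is expected to land near 25 nM, with a plausible range from 5 nM to 120 nM.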

Compound 4, inhibition constant: 525 nM
Compound 4: middle estimate off by 21-fold (1.32 log units), on the low side; measured number above the stated range.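

No step can be read between compound 1 and compound 4: compound 1 stands without a number. The compounds shown leave open what iodo in place of hydrogen does here, and no measurement shown explains the result for compound 4.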